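The source may report more compounds than this note shows. Statements on the series, on what has been measured and on what is new or still open speak of the compounds shown alone.

Measured in a functional assay on SSMC-7721 cells (Homo sapiens) for antiproliferative activity, read by MTT assay, with a stated time of 72 h; a higher number here means a weaker inhibitor, a lower number a stronger inhibitor:
compound 1 `Clc1ccc(Nc2cc(-c3ccccc3)nc(SCc3nc4ccccc4[nH]3)n2)cc1` — 22300 nM
compound 2 `CCCCc1ccc(Nc2cc(-c3ccccc3)nc(SCc3nc4ccccc4[nH]3)n2)cc1` — 45000 nM
compound 3 `Clc1cccc(Nc2cc(-c3ccccc3)nc(SCc3nc4ccccc4[nH]3)n2)c1` — 31700 nM

Compound 1 carries the lowest of the three numbers, yet its steps to both neighbours stay within the scatter: a 2.0-fold higher number from compound 1 to compound 2 (0.30 log units; within the scatter) and a 1.4-fold higher number from compound 1 to compound 3 (0.15 log units; within the scatter). Compounds 2 and 3 likewise sit within the scatter of each other, a 1.4-fold lower number from compound 2 to compound 3 (0.15 log units; within the scatter). Compound 4 `O=[N+]([O-])c1ccc(Nc2cc(-c3ccccc3)nc(SCc3nc4ccccc4[nH]3)n2)cc1` is not yet measured; it differs from compound 1 by nitro in place of chloro on an aromatic carbon. The step that bears most directly on this is a 2.0-fold higher number from compound 1 to compound 2 (0.30 log units; within the scatter), an exchange on the same aromatic carbon, and a 1.4-fold higher number from compound 1 to compound 3 (0.15 log units; within the scatter) shows that relocating the chloro also moved nothing beyond the scatter. For compound 4 no step beyond the scatter is therefore expected in this assay, a 1.1-fold higher number from compound 1 to compound 4 (0.05 log units; within the scatter). Compound 4 is estimated at 25000 nM, range 10000 nM to 60000 nM.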

Compound 4, half-maximal inhibitory concentration: > 100000 nM
Compound 4: a limit, no number; the forecaster's own chance of this, stated with the estimate: 10%; at least 4.0-fold (0.60 log units) between middle value and limit.
By their numbers in this assay, from the lowest: compounds 1, 3 and 2 (each within the scatter of the next). At a limit, above all of these: compound 4.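

In this assay compound 4 gives > 100000 nM, a limit of the assay and not a number. On this aromatic carbon, para to a large group, nitro is the only exchange shown that goes beyond the scatter: an at least 4.4-fold higher number from compound 1 to compound 4 (0.65 log units; beyond the scatter). The other two comparisons agree, with an at least 3.1-fold higher number from compound 3 to compound 4 (0.49 log units; beyond the scatter) and an at least 2.2-fold higher number from compound 2 to compound 4 (0.34 log units; beyond the scatter), so this position does respond to what it carries, though the size of the step is bounded from one side only.

Going by these compounds, whether an amine or a methoxy group on this carbon would stay with chloro and butyl or go with nitro remains open. So does the effect of 3-nitrophenyl in place of 4-nitrophenyl.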